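From Hexyl to Cyclohexylmethyl on a Shared Core

The source may report more compounds than this note shows. Statements on the series, on what has been measured and on what is new or still open speak of the compounds shown alone.

- Compound 1 `COc1cccc(OCCC(C)(C)C)c1C(=O)/C=C/c1ccc(O)cc1` gives > 30000 nM (a limit)
- Compound 2 `CCCCCCOc1cccc(O)c1C(=O)/C=C/c1ccc(O)cc1` gives > 30000 nM (a limit)

Both results come from a functional assay on PC-3 cells (Homo sapiens) for antiproliferative activity, read by sulforhodamine B assay; on this read-out higher numbers stand for weaker inhibition of growth and lower numbers for stronger inhibition of growth. In this assay compound 2 gives > 30000 nM, which is a limit of the assay and not a number. Compound 1 is no different in kind, since its > 30000 nM is also a limit. Together they make up the whole record so far: the limit of > 30000 nM in this assay, at which 2 of the 2 values shown sit.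

The next compound, compound 3 `O=C(/C=C/c1ccc(O)cc1)c1c(O)cccc1OCC1CCCCC1`, has not yet been measured. Its difference from compound 2 is cyclohexyl in place of pentyl on a saturated chain carbon bound to an oxygen on an aromatic ring. In words, cyclohexyl takes the place of pentyl on a saturated chain carbon bound to an oxygen on an aromatic ring, so hexyloxy becomes cyclohexylmethoxy.

Among the compounds with values here, no measured pair shows what a change of this kind does, and a limit gives no true starting number. The expectation is therefore for no step beyond the usual scatter, in either direction. The estimated a number no higher from compound 2 to compound 3 (the limit leaves the size open) reflects that expectation, and another limit is the likeliest report. For compound 3 the expected value is 30000 nM, with an estimated range of 12000 nM to 60000 nM.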

Compound 3, concentration for 50% growth inhibition: > 30000 nM
Compound 3: no number, only a limit; the forecaster's own chance of this, stated with the estimate: 70%; the middle value sits exactly at the limit.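

In this assay compound 3 gives > 30000 nM and that is a limit of the assay, not a number. Compound 2 also stands at a limit, so the change from hexyl to cyclohexylmethyl between compound 2 and compound 3 cannot be read as a step. The record now shows: the limit of > 30000 nM in this assay, at which 3 of the 3 values shown sit.

Going by these compounds, whether this assay would return a true number for any compound on the shared core stays open.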